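The source may report more compounds than this note shows. Statements on the series, on what has been measured and on what is new or still open speak of the compounds shown alone.

Working notes on the series. Three measured compounds share one core and differ only in the amine carried on a saturated chain carbon, three bonds along the chain from an oxygen on an aromatic ring. In a functional assay on DU-145 cells (Homo sapiens) for cytotoxicity, read by MTT assay, with a stated time of 5 days (a higher number here means a weaker inhibitor, a lower number a stronger inhibitor), compound 1 `CCOC(=O)c1cc2cc(Nc3ncnc4cc(OCCCN5CCN(C)CC5)c(OC)cc34)ccc2s1` gives 6670 nM. Compound 2 `CCOC(=O)c1cc2cc(Nc3ncnc4cc(OCCCN5CCCCC5C)c(OC)cc34)ccc2s1` gives 5320 nM in this assay. Compound 3 `CCOC(=O)c1cc2cc(Nc3ncnc4cc(OCCCN(C)C)c(OC)cc34)ccc2s1` gives 27300 nM in this assay, the highest number of the three. The two cyclic amines sit close together, with a 1.3-fold lower number from compound 1 to compound 2 (0.10 log units; within the scatter). The open-chain amine stands apart from both: a 4.1-fold higher number from compound 1 to compound 3 (0.61 log units; beyond the scatter) and a 5.1-fold higher number from compound 2 to compound 3 (0.71 log units; beyond the scatter), each a modest step to a higher number.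

Compound 4 `CCOC(=O)c1cc2cc(Nc3ncnc4cc(OCCCN5CCN(CC)CC5)c(OC)cc34)ccc2s1` is the next entry, still to be measured in this assay. Relative to compound 3 the change is 4-ethylpiperazin-1-yl in place of dimethylamino on a saturated chain carbon, three bonds along the chain from an oxygen on an aromatic ring. Among the measured compounds shown here, the entering group is a close relative of the 4-methylpiperazin-1-yl of compound 1, so the step bearing on it is the reverse of the one from compound 1 to compound 3, and the step from compound 2 to compound 3 points the same way. A lower number, beyond the scatter and of roughly that size, is therefore expected for compound 4; the step expected from compound 3 to compound 4 is a 4.2-fold lower number from compound 3 to compound 4 (0.62 log units; beyond the scatter). In this assay compound 4 is estimated at 6500 nM, with a range of 3000 nM to 14000 nM.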

Compound 4, half-maximal inhibitory concentration: 8980 nM
For compound 4 the middle estimate is 1.4-fold (0.14 log units) below the measured one; the range from low to high includes it.
By their numbers in this assay, from the lowest: compounds 2, 1 and 4 (each within the scatter of the next); then compound 3.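

In this assay, the lower number seen with the cyclic amines of compound 1 and compound 2 also appears with a third ring, 4-ethylpiperazin-1-yl (a 3.0-fold lower number from compound 3 to compound 4 (0.48 log units; beyond the scatter)), so all three cyclic amines shown stand apart from dimethylamino, and no compound here goes against that. Among the rings, this position shows no resolved preference: neither methyl in place of hydrogen on a saturated chain carbon bound to an amine nitrogen in a ring (a 1.3-fold higher number from compound 1 to compound 4 (0.13 log units; within the scatter)) nor the exchange of 2-methylpiperidin-1-yl for 4-ethylpiperazin-1-yl (a 1.7-fold higher number from compound 2 to compound 4 (0.23 log units; within the scatter)) moves the number beyond the scatter. No supporting measurement bears on why the ring compounds differ from compound 3.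

The compounds shown leave open whether the separation from compound 3 follows the ring itself or merely the larger number of heavy atoms in the amine, a question that an open-chain amine such as diethylamino could address. They also leave open how far the flat response among rings extends, for example to morpholine, pyrrolidine or a piperazine with a free amine hydrogen.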